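The compounds below may be only part of what the source reports. "The series", "measured", "known", "first", "only" and "open" are said of these compounds alone.

Within the data shown here, in a functional assay on MCF7 cells (Homo sapiens) for cytotoxicity, read by MTT assay (a higher number here means a weaker inhibitor, a lower number a stronger inhibitor), compound 1 (`CC(C)C[C@@H](NC(=S)Nc1cc(C(F)(F)F)cc(C(F)(F)F)c1)c1nc2ccccc2[nH]1`) gives 91000 nM, the higher of the two numbers so far, and compound 2 (`CC(C)C[C@H](NC(=S)Nc1cc(C(F)(F)F)cc(C(F)(F)F)c1)c1nc2ccccc2[nH]1`) gives 16300 nM. Compound 3 (`C[C@@H](NC(=S)Nc1cc(C(F)(F)F)cc(C(F)(F)F)c1)c1nc2ccccc2[nH]1`) has hydrogen in place of isopropyl on a saturated chain carbon, two bonds along the chain from an amide-type nitrogen and an aromatic carbon. Among the measured compounds shown here, the only measured step, a 5.6-fold lower number from compound 1 to compound 2 (0.75 log units; beyond the scatter), goes with the fact that compounds 1 and 2 differ only in the configuration as drawn. It leaves the chain untouched, so it serves only as a gauge of size. A step no larger is expected in this assay, leaning weakly towards a lower number. The expected step is a 1.5-fold lower number from compound 1 to compound 3 (0.18 log units; within the scatter). For compound 3 the estimated value is 60000 nM, with an expected range of 18000 nM to 150000 nM.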

Compound 3, half-maximal inhibitory concentration: 10300 nM
Compound 3: middle estimate off by 5.8-fold (0.77 log units), on the high side; measured number below the stated range.
By their numbers in this assay, from the lowest: compounds 3 and 2 (each within the scatter of the next); then compound 1.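

In this assay the isobutyl chain of compound 1 is not needed at this saturated chain carbon: the change to methyl brings an 8.8-fold lower number from compound 1 to compound 3 (0.95 log units; beyond the scatter). Among these compounds, the number at this position therefore moves with the substituent itself, whereas the earlier compounds showed only a change of configuration. Nothing measured here accounts for this step.

Open, on these data alone, is how the number runs between and beyond these groups, with ethyl, a longer chain or an amine at this carbon. Also open, as far as these compounds go, is what the opposite configuration does in the methyl compound.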